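A few compounds are considered here, and "the series" means these few. Any claim that something is new, unique, unknown or untested is made for them only; others in the source may bear on it.

Within the data shown here, compound 2 (`O=Cc1cccc(OCc2ccc3no[n+]([O-])c3c2)c1`) gives 50 uM in an ADME assay on cells (Erythrocyte, Homo sapiens), read by spectrophotometry and hemolysis, with a stated time of 24 h (a lower number here means a stronger inhibitor, a higher number a weaker inhibitor), and is the only compound so far with a true number. Compound 1 (`NC(=S)N/N=C/c1ccc(OCc2ccc3no[n+]([O-])c3c2)cc1`) gives > 200 uM as a limit of the assay and not a number. Compound 3 (`CC(=O)c1ccccc1OCc1ccc2no[n+]([O-])c2c1`) gives > 200 uM as a limit too. Compound 4 (`N=C(N)N/N=C/c1cccc(OCc2ccc3no[n+]([O-])c3c2)c1`) swaps the formyl group of compound 2 for a larger chain on the same aromatic carbon (a group of 6 heavy atoms (2 carbon, 4 nitrogen; no ring) in place of a group of 2 heavy atoms (1 carbon, 1 oxygen; no ring), on an aromatic carbon). Among the measured compounds shown here, the one hint is compound 1, with a nitrogen-bearing chain of its own at > 200 uM as a limit. Compound 3 goes against that hint, reaching a limit with no such chain. In this assay a moderate rise toward a weaker effect is therefore expected, on thin evidence. The expected step runs a 2.4-fold higher number from compound 2 to compound 4 (0.38 log units; beyond the scatter) and is only an estimate. Compound 4 is expected at 120 uM with a likely range of 40 uM to 350 uM in this measurement.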

Compound 4, concentration for 50% inhibition: > 100 uM
Compound 4: a limit, no number (the forecaster's own chance of this, stated with the estimate: 45%); the middle value is on the limit's open side.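

Swapping the formyl group on this aromatic carbon for the chain of 6 heavy atoms gives an at least 2.0-fold higher number from compound 2 to compound 4 (0.30 log units; that floor lies within the scatter) in this assay. This is the first one-place change shown at this position, and it brings no lower number, so the new chain shows no stronger effect than the formyl group. The true size of the step cannot be fixed because compound 4 sits at a limit of the assay: the limit of > 100 uM in this assay, at which 1 of the 4 values shown sits.

On these data alone, how far beyond its limit compound 4 lies remains open. So does whether a smaller group here, such as an amine or a carboxylic acid, would give a true number.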